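Ethoxy in place of trifluoromethyl: expected activation

A few compounds are considered here, and "the series" means these few. Any claim that something is new, unique, unknown or untested is made for them only; others in the source may bear on it.

Compound 1 `Cc1ccc(-c2ccc(NCc3ccccc3O)cc2)cc1` has been run in a functional assay on Jurkat cells (Homo sapiens) for activation, with a stated time of 24 h (on this read-out lower numbers stand for an effect already at smaller amounts and higher numbers for an effect only at larger amounts of compound), where compound 1 gives 3790 nM. Compound 2 `Oc1ccccc1CNc1ccc(-c2ccc(C(F)(F)F)cc2)cc1` is the second measured member of the series; in this assay compound 2 is reported as "not active" (no number reported), so no single number stands for it and no comparison with compound 1 can be put in size. Compound 3 `CCOc1ccc(-c2ccc(NCc3ccccc3O)cc2)cc1` differs from compound 2 by ethoxy in place of trifluoromethyl on an aromatic carbon. Within the data shown here, since compound 2 has no number, no step from compound 2 to compound 3 can be stated; the only figure available is the weak activation of compound 1. The expectation for compound 3 is therefore modest activation at best, in the region seen for compound 1, with a real chance that no number is returned. Compound 3 is expected to give about 4500 nM in this assay, estimated between 1200 nM and 20000 nM.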

Compound 3, half-maximal effective concentration: 520 nM
Compound 3: the middle estimate sits 8.7-fold (0.94 log units) above what was measured; the whole stated range lies above it.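

Changing methyl to ethoxy at this position gives a 7.3-fold lower number from compound 1 to compound 3 (0.86 log units; beyond the scatter), so the read-out in this assay responds clearly to the group placed here, and compound 3 shows that the group can move the number in the favourable direction, not only toward the "not active" report of compound 2. Steps involving compound 2 cannot be read, as it carries no number, so the size of the change from trifluoromethyl to ethoxy remains unknown. No measurement at hand accounts for the shift.

From the compounds shown here alone, it remains open whether the lower number follows the ether oxygen or the longer chain; methoxy and propyl at this place would separate the two. Also open, going by these compounds, is how far the position reaches: butoxy, an amine or a carboxylic acid here would test that.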